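Nitroimidazole oxazine series: Vero cytotoxicity, compound 3 to compound 4

The source may report more compounds than this note shows. Statements on the series, on what has been measured and on what is new or still open speak of the compounds shown alone.

Working notes. The three measured compounds share a core with a nitroimidazole oxazine attached to a bicyclic amine: compound 1 `C[C@]1(CN2CCc3nc(-c4ccc(F)cc4)oc3C2)Cn2cc([N+](=O)[O-])nc2O1`, compound 2 `C[C@]1(CN2CCc3sc(-c4ccc(F)cc4)nc3C2)Cn2cc([N+](=O)[O-])nc2O1` and compound 3 `C[C@]1(CN2CCc3nc(-c4ccc(C(F)(F)F)cc4)ccc3C2)Cn2cc([N+](=O)[O-])nc2O1`. In an ADME assay on Vero cells (Chlorocebus sabaeus) for cytotoxicity, read by MTT assay, with a stated time of 72 h (on this read-out lower numbers stand for higher toxicity in this test and higher numbers for lower toxicity in this test), compound 1 reports only a limit, > 32 ug/mL. For compound 2 the entry in this assay is "not determined" (no result reported), with no result reported. Compound 3 likewise reports only a limit in this assay, > 32 ug/mL. For the measured compounds named here, compound 3 therefore stands at the limit where the other numerical entry also sits (the limit of > 32 ug/mL in this assay, at which 2 of the 3 values shown sit); no step between measured compounds can be sized, and no compound can be ordered against another.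

Compound 4 `C[C@]1(CN2CCc3nc(-c4ccc(Cl)cc4F)ccc3C2)Cn2cc([N+](=O)[O-])nc2O1` is not yet measured. It differs from compound 3 by 4-chloro-2-fluorophenyl in place of 4-(trifluoromethyl)phenyl on an aromatic carbon.

With both available values at the limit, the step from compound 3 to compound 4 in this assay is expected to stay within the scatter, a step that the limit leaves unreadable from compound 3 to compound 4, and most likely to be reported again as a limit. Compound 4 is expected to give 40 ug/mL in this assay, within 16 ug/mL to 100 ug/mL.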

Compound 4, half-maximal cytotoxic concentration: > 32 ug/mL
Compound 4: a limit, no number (the forecaster's own chance of this, stated with the estimate: 80%); the middle value is on the limit's open side.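

In this assay compound 4 reports only a limit, > 32 ug/mL, so no step can be read between compound 3 and compound 4, which sit at the same limit: the limit of > 32 ug/mL in this assay, at which 3 of the 4 values shown sit.

The compounds shown leave open where the half-maximal cytotoxic concentration of any of them actually lies.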